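Swapping a Methoxyethyl Chain for Cyclopentyl on the Core

The source may report more compounds than this note shows. Statements on the series, on what has been measured and on what is new or still open speak of the compounds shown alone.

Compound 1 (`COCC/C(=C(/c1ccc(/C=C/C(=O)O)cc1)c1ccc2[nH]ncc2c1)c1ccccc1`) gives 63 nM in a functional assay on MCF7 cells (Homo sapiens) for cytotoxicity, read by CellTiter-Glo, with a stated time of 5 days; on this read-out higher numbers stand for weaker inhibition and lower numbers for stronger inhibition.
Compound 2 (`O=C(O)/C=C/c1ccc(/C(=C(\c2ccccc2)C2CCC2)c2ccc3[nH]ncc3c2)cc1`) gives 1.4 nM in this assay.

Compound 1 stands at the higher of the two numbers; its nearest neighbour is compound 2, reached by a 45-fold lower number from compound 1 to compound 2 (1.65 log units; beyond the scatter). Compound 3 (`O=C(O)/C=C/c1ccc(/C(=C(\c2ccccc2)C2CCCC2)c2ccc3[nH]ncc3c2)cc1`) differs from compound 1 by cyclopentyl in place of 2-methoxyethyl on a double-bonded chain carbon bound to an aromatic carbon and a double-bonded chain carbon. Among the measured compounds shown here, the only measured step that bears on this is the one in which cyclobutyl replaced the same chain, and that step was large. Cyclopentyl closely resembles cyclobutyl, so a comparably large downward step in this assay is expected, a 32-fold lower number from compound 1 to compound 3 (1.50 log units; beyond the scatter). Compound 3 is therefore estimated at 2 nM, with a range from 0.6 nM to 7 nM.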

Compound 3, half-maximal inhibitory concentration: 10 nM
Compound 3: middle estimate off by 5.0-fold (0.70 log units), on the low side, and the stated range ends below it.
By their numbers in this assay, from the lowest: compound 2; then compound 3; then compound 1.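

In this assay, having a ring at this position does not settle the outcome: cyclopentyl still beats 2-methoxyethyl, with a 6.3-fold lower number from compound 1 to compound 3 (0.80 log units; beyond the scatter), yet replacing cyclobutyl with cyclopentyl gives a 7.1-fold higher number from compound 2 to compound 3 (0.85 log units; beyond the scatter). Ring size therefore matters here, and among these three compounds the cyclobutyl of compound 2 gives the lowest number. Nothing available here gives a reason for the gap between the two rings. Going by these compounds, it remains open whether the smaller cyclopropyl ring would give a lower number still, and how a branched open chain such as isopropyl or an oxygen-containing ring such as tetrahydrofuranyl would compare.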